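A few compounds are considered here, and "the series" means these few. Any claim that something is new, unique, unknown or untested is made for them only; others in the source may bear on it.

In a functional assay on BaF3 cells (Mus musculus) for antiproliferative activity, read by CCK-8 assay and cell counting, with a stated time of 76 h (a lower number here means a stronger inhibitor, a higher number a weaker inhibitor), compound 1 `COc1cc2nccc(Oc3ccc(Nc4nn(C)cc4C(=O)NC4CCCCC4)cc3)c2cc1C(N)=O`, with cyclohexyl on an amide-type nitrogen, gives 4800 nM. Compound 2 `COc1cc2nccc(Oc3ccc(Nc4nn(C)cc4C(=O)NCC4CCCO4)cc3)c2cc1C(N)=O` gives > 10000 nM, which is a limit and not a number, so it stands at the limit of > 10000 nM in this assay, at which 1 of the 2 values shown sits. Going by the values given here, the only measured step is an at least 2.0-fold higher number from compound 1 to compound 2 (0.31 log units; beyond the scatter), and it came with (oxolan-2-yl)methyl in place of cyclohexyl. Compound 3 `COc1cc2nccc(Oc3ccc(Nc4nn(C)cc4C(=O)NCC(C)C)cc3)c2cc1C(N)=O` differs from compound 2 by isopropyl in place of oxolan-2-yl on a saturated chain carbon bound to an amide-type nitrogen, which gives an isobutyl group. Like the cyclohexyl of compound 1 at 4800 nM, this group holds only carbon, so a modest move to a lower number is expected in this assay. The expected step is an at least 1.5-fold lower number from compound 2 to compound 3 (0.18 log units; that floor lies within the scatter). For compound 3 the estimated value is 6500 nM, with an expected range of 3000 nM to 10000 nM.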

Compound 3, half-maximal inhibitory concentration: > 10000 nM
Compound 3 was reported as a limit; the forecaster's own chance of this, stated with the estimate: 30%; at least 1.5-fold (0.18 log units) between middle value and limit.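

In this assay compound 3 is a limit and not a number, so its step from compound 2, also a limit, cannot be read: the limit of > 10000 nM in this assay, at which 2 of the 3 values shown sit. Even so, isobutyl in place of cyclohexyl on the amide-type nitrogen gives an at least 2.0-fold higher number from compound 1 to compound 3 (0.31 log units; beyond the scatter), so a group holding only carbon does not by itself match cyclohexyl at this position. Of the three groups shown, only the cyclohexyl of compound 1 gives a measured number, 4800 nM.

The compounds shown leave open whether a cyclopentyl or benzyl group, or a chain ending in an amine, on this nitrogen would give a lower number than compound 1. They also leave open how compound 2 and compound 3 rank against each other.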